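Methyl addition on the shared core: expected step

A few compounds are considered here, and "the series" means these few. Any claim that something is new, unique, unknown or untested is made for them only; others in the source may bear on it.

Measured so far in a physicochemical assay for solubility, measured as kinetic solubility, at pH 7.4; on this read-out higher numbers stand for higher solubility and lower numbers for lower solubility:
- compound 1 `Cc1csc2nc(Cn3cnc4ccccc43)cc(=O)n12` gives 117000 nM
- compound 2 `O=c1cc(Cn2cnc3ccccc32)nc2sccn12` gives 569000 nM

Among the measured compounds shown here, compound 1 stands as the lower of the two measured numbers, and compound 2 is its only neighbour. Compound 3 `Cc1sc2nc(Cn3cnc4ccccc43)cc(=O)n2c1C` has not yet been measured. It differs from compound 1 by methyl in place of hydrogen on an aromatic carbon, next to the ring sulfur and next to the ring atom that bears a methyl group (methyl in place of hydrogen on an aromatic carbon).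

For the measured compounds named here, one measured step bears on this change: a 4.9-fold higher number from compound 1 to compound 2 (0.69 log units; beyond the scatter), modest and beyond the scatter, with hydrogen in place of methyl on an aromatic carbon. That step takes a methyl away, whereas compound 3 gains one at another aromatic carbon. It is a single pair, so the transfer is uncertain. A modest step of similar size towards a lower number is therefore expected in this assay.

The estimated step is a 3.3-fold lower number from compound 1 to compound 3 (0.52 log units; beyond the scatter), with wide uncertainty. For compound 3 the expected value is 35000 nM, within an estimated range of 12000 nM to 90000 nM.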

Compound 3, solubility: 141000 nM
Estimate against measurement, compound 3: 4.0-fold (0.61 log units) below, outside the stated range (above it).
By their numbers in this assay, from the lowest: compounds 1 and 3 (each within the scatter of the next); then compound 2.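

In this assay, methyl in place of hydrogen on the aromatic carbon next to the ring sulfur gives a 1.2-fold higher number from compound 1 to compound 3 (0.08 log units; within the scatter), so compound 3 cannot be told apart from compound 1 on this read-out. Among the compounds shown here, the only other step on the shared core, a 4.9-fold higher number from compound 1 to compound 2 (0.69 log units; beyond the scatter), exchanges hydrogen for methyl at a different aromatic carbon and lies beyond the scatter, so in these compounds the size of a methyl step at one carbon does not carry over to the other. Nothing measured here accounts for the difference between the two carbons.

From the compounds shown here alone, what a group other than methyl, such as an amine, a carboxylic acid or a longer chain, would do at the carbon next to the ring sulfur in this assay remains open. Going by these compounds, the step at this carbon is also read only with a methyl group on the other ring atom, so whether methyl here would give a step of similar size on the core of compound 2 remains open too.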